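This account rests on a few compounds, and the source may have more. Where it says the series, first, only, none or still open, it means among the compounds named here.

Measured so far in a functional assay on K562 cells (Homo sapiens) for cytotoxicity, read by MTT assay, with a stated time of 72 h; on this read-out higher numbers stand for weaker inhibition and lower numbers for stronger inhibition:

compound 1 `CCOc1ccc(COc2c(OC)cc(/C=C/C(=O)OCC(=O)Nc3ccccc3)cc2OC)cc1` gives > 200000 nM as a limit
compound 2 `O=C(COC(=O)/C=C/c1ccc(O)c(O)c1)NN1CCOCC1` gives 56800 nM as a number
compound 3 `COc1cc(/C=C/C(=O)OCC(=O)Nc2ccc(Cl)cc2)cc(OC)c1OCc1ccc(Cl)c(Cl)c1` gives > 200000 nM as a limit

Within the data shown here, compound 2 is the only compound here with an actual number, and the other two sit at a limit (the limit of > 200000 nM in this assay, at which 2 of the 3 values shown sit). Next in line is compound 4 `COc1ccc(NC(=O)COC(=O)/C=C/c2ccc(O)c(O)c2)cc1`, which differs from compound 2 by 4-methoxyphenyl in place of morpholin-4-yl on an amide-type nitrogen. The rest of compound 2 stays unchanged. Among the measured compounds shown here, compound 1 and compound 3 also carry an aromatic ring on an amide-type nitrogen, but they differ from compound 4 elsewhere as well, so no measured pair isolates this change. With only compound 2 at 56800 nM as an anchor, no step beyond the scatter is expected in this assay, although a result on the weaker side remains possible. The expected step is a 1.1-fold lower number from compound 2 to compound 4 (0.06 log units; within the scatter) as an estimate. For compound 4 the estimated value is 50000 nM with an expected range from 15000 nM to 170000 nM in this assay.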

Compound 4, half-maximal inhibitory concentration: 79100 nM
Beside the measured number, compound 4's estimate is 1.6-fold (0.20 log units) below it, within the range that was stated.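

In this assay, 4-methoxyphenyl in place of morpholin-4-yl on an amide-type nitrogen gives a 1.4-fold higher number from compound 2 to compound 4 (0.14 log units; within the scatter). Among these compounds, this is the first comparison here that isolates a single change at this position, and it shows that a six-membered aromatic ring of carbon only and a six-membered non-aromatic ring with 2 hetero atoms can be exchanged there with the read-out staying within the scatter. Compound 4 carries an aromatic ring on this nitrogen and still gives a number, so such a ring alone does not put a compound at the limit: the limit of > 200000 nM in this assay, at which 2 of the 4 values shown sit.

From the compounds shown here alone, compound 1 and compound 3 differ from compound 4 in more than one place, so what separates their limit values from its number stays open. Also open, going by these compounds, is how a piperazin-1-yl group or a 4-carboxyphenyl group would read on this same nitrogen.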